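Working notes on amide variation across compounds 1 to 4

The source may hold more compounds than are shown below. What is called first, only, known or untested is meant among the compounds shown, and "the series" means these compounds.

Measured so far:
compound 1 `C=C(C)C(=O)Nc1cc2c(N3CCc4ccccc43)ncnc2cc1OC` — 4830 nM
compound 2 `C=C(C)C(=O)Nc1cc2c(N3CCc4ccccc43)ncnc2cc1O[C@@H]1CCOC1` — 4910 nM
compound 3 `C/C=C/C(=O)Nc1cc2c(N3CCCc4ccccc43)ncnc2cc1O[C@@H]1CCOC1` — 9350 nM

In a functional assay on PC-3 cells (Homo sapiens) for antiproliferative activity, read by MTT assay, with a stated time of 72 h (on this read-out higher numbers stand for weaker inhibition and lower numbers for stronger inhibition), compound 1 gives the lowest of the three numbers, yet compound 2 sits within the scatter of it and compound 3 also does, so no ordering among the three is claimed. Going by the values given here, the one single-place step, a 1.0-fold higher number from compound 1 to compound 2 (0.01 log units; within the scatter), concerns the ether on the aromatic ring, not the amide. Compound 4 `COc1cc2ncnc(N3CCc4ccccc43)c2cc1NC(=O)/C=C/CN1CCN(C)CC1` changes the amide instead: 3-(4-methylpiperazin-1-yl)prop-1-en-1-yl in place of 1-methylethenyl on a carbonyl carbon. Among the compounds with values here, no measured step touches that position, so the step of a 1.1-fold lower number from compound 1 to compound 4 (0.03 log units; within the scatter) is expected to stay within the scatter. For compound 4 an inhibitory concentration of 4500 nM is estimated, with a range of 1500 nM to 13000 nM.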

Compound 4, half-maximal inhibitory concentration: 9180 nM
Compound 4: the middle estimate sits 2.0-fold (0.31 log units) below what was measured; the measured number falls inside the stated range.
By their numbers in this assay, from the lowest: compounds 1, 2, 4 and 3 (each within the scatter of the next).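

In this assay, going by these compounds alone, the first measured step at the carbonyl carbon is a 1.9-fold higher number from compound 1 to compound 4 (0.28 log units; within the scatter), with 3-(4-methylpiperazin-1-yl)prop-1-en-1-yl and its 10 heavy atoms in place of the 3 of 1-methylethenyl. At this position, then, the larger group with a six-membered non-aromatic ring gives no step beyond the scatter. No supporting data bear on this result.

Still open, as far as these compounds go, is how a dimethylamino or morpholin-4-yl group on the same prop-1-en-1-yl chain would read. From the compounds shown here alone, the same amide change alongside the oxolan-3-yl ether also remains open.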